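The compounds below may be only part of what the source reports. "The series", "measured", "known", "first", "only" and "open" are said of these compounds alone.

Compound 1 `O=C(O)CCc1ccc(C#Cc2ncccc2[N+](=O)[O-])cc1` and compound 2 `Cc1ccsc1C#Cc1ccc(CCC(=O)O)cc1` have both been measured in an in vitro functional assay on 1321-N1 cells for agonist activity at Free fatty acid receptor 1 (Homo sapiens), read by fluorescence, spectrophotometry and calcium flux; on this read-out higher numbers stand for an effect only at larger amounts of compound and lower numbers for an effect already at smaller amounts. Compound 1 gives 11000 nM, whereas compound 2 gives 75.9 nM, the lowest of the two numbers and a gap from compound 1 that lies beyond the usual scatter. Compound 3 `O=C(O)CCc1ccc(C#Cc2ccccn2)cc1` is not yet measured. It differs from compound 2 in one place: pyridin-2-yl in place of 3-methylthiophen-2-yl on a triple-bonded carbon. Among the compounds with values here, no measured pair shows this change directly. The expected step is a 6.6-fold higher number from compound 2 to compound 3 (0.82 log units; beyond the scatter), a move toward a higher number that is expected to go beyond the scatter. Compound 3 is estimated to give about 500 nM, within a range from 100 nM to 3000 nM.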

Compound 3, half-maximal effective concentration: 13200 nM
For compound 3 the middle estimate is 26-fold (1.42 log units) below the measured one; measured number above the stated range.
By their numbers in this assay, from the lowest: compound 2; then compounds 1 and 3 (each within the scatter of the next).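

In this assay, the group on the triple-bonded carbon carries great weight: pyridin-2-yl in place of 3-methylthiophen-2-yl gives a 170-fold higher number from compound 2 to compound 3 (2.24 log units; beyond the scatter). On the pyridin-2-yl ring, hydrogen in place of nitro on an aromatic carbon gives a 1.2-fold higher number from compound 1 to compound 3 (0.08 log units; within the scatter), so the nitro group shifts nothing that can be told from the scatter. No measured evidence here accounts for the large step. Still open, as far as these compounds go, is whether the ring itself or its methyl group matters more for the lower number of compound 2. An amine or a methoxy group on the pyridin-2-yl ring also remains untested among the compounds shown.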